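The source may hold more compounds than are shown below. What is called first, only, known or untested is meant among the compounds shown, and "the series" means these compounds.

In a functional assay on HeLa cells (Homo sapiens) for cytotoxicity, read by MTT assay (a higher number here means a weaker inhibitor, a lower number a stronger inhibitor), compound 1 (`CC[C@](C)(O)CC(=O)O[C@H](CC=C(C)C)C1=CC(=O)c2c(O)ccc(O)c2C1=O`) gives 30200 nM and compound 2 (`CCC(O)CO[C@H](CC=C(C)C)C1=CC(=O)c2c(O)ccc(O)c2C1=O`) gives 28700 nM on the shared core. Among the compounds with values here, the one measured step, a 1.1-fold lower number from compound 1 to compound 2 (0.02 log units; within the scatter), lies within the scatter, so compound 2 stands level with compound 1 and the two cannot be ranked. Compound 3 (`CCC(CO[C@H](CC=C(C)C)C1=CC(=O)c2c(O)ccc(O)c2C1=O)OC(C)=O`) has not yet been measured. It departs from compound 2 by acetyl in place of hydrogen on an oxygen on a saturated carbon as 2-hydroxybutyl becomes 2-acetoxybutyl. Within the data shown here, no measured pair shows this exact change, so the evidence is indirect. The nearest guide is a 1.1-fold lower number from compound 1 to compound 2 (0.02 log units; within the scatter), which also alters the group on an oxygen on a saturated carbon and stays within the scatter. In this assay the expected change is therefore no step beyond the scatter and no firm direction, with an estimated 1.1-fold lower number from compound 2 to compound 3 (0.06 log units; within the scatter) as the middle case. For compound 3 the estimated value is 25000 nM with an expected range from 11000 nM to 50000 nM for now.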

Compound 3, half-maximal inhibitory concentration: 44000 nM
Compound 3: middle estimate off by 1.8-fold (0.25 log units), on the low side, and the stated range covers the measured number.
By their numbers in this assay, from the lowest: compounds 2, 1 and 3 (each within the scatter of the next).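

In this assay, the change at this oxygen on a saturated carbon, acetyl in place of hydrogen, now has a direct reading: a 1.5-fold higher number from compound 2 to compound 3 (0.19 log units; within the scatter), so the hydroxy of 2-hydroxybutyl can give way to acetoxy without a step beyond the scatter. Putting 2-acetoxybutyl in place of (2-hydroxy-2-methylbutyl)carbonyl gives a 1.5-fold higher number from compound 1 to compound 3 (0.16 log units; within the scatter), so the three groups on this oxygen stand level and cannot be ranked. Nothing measured here bears on a cause for these numbers.

The compounds shown leave open whether an amine, a carboxylic acid or a longer acyl chain on this oxygen would produce a step beyond the scatter. They also leave open whether the hydroxy or acetoxy group would matter on a shorter chain, such as 1-hydroxypropyl or 1-acetoxypropyl.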